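The source may report more compounds than this note shows. Statements on the series, on what has been measured and on what is new or still open speak of the compounds shown alone.

Measured so far:
- compound 1, `CC(C)(C)c1cc2n(n1)CCN(C(=O)c1ccc3ccccc3c1)C2`: 477 nM
- compound 2, `O=C(c1ccccc1)N1CCn2nc(-c3cccnc3)cc2C1`: > 10000 nM
- compound 3, `O=C(c1ccccc1Cl)N1CCn2nc(-c3ccccn3)cc2C1`: 2480 nM

All three compounds share the same core and were tested in a functional assay on HEK293 cells for negative allosteric modulation of metabotropic glutamate receptor 5 (Homo sapiens), read by calcium flux, with a stated time of 20 min; on this read-out lower numbers stand for stronger inhibition and higher numbers for weaker inhibition. Compound 2 gives > 10000 nM, which is a limit of the assay rather than a number; it is the case described by the limit of > 10000 nM in this assay, at which 1 of the 3 values shown sits. Among the two compounds with real numbers, compound 3 has the higher one, and compound 1 has the lower one, a gap that lies beyond the usual scatter.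

Compound 4, `O=C(c1ccc(Cl)cc1)N1CCn2nc(-c3ccccn3)cc2C1`, has not been measured. It differs from compound 3 in one place: 4-chlorophenyl in place of 2-chlorophenyl on a carbonyl carbon. The two have the same atoms, joined differently, so only the position of the chlorine on the benzoyl ring changes. For the measured compounds named here, no measured pair in this set isolates such a move, so there is no direct guide to its size or direction.

The step from compound 3 to compound 4 is therefore expected to be small, a 1.2-fold lower number from compound 3 to compound 4 (0.09 log units; within the scatter), with no clear direction beyond the scatter. Compound 4 is estimated to give 2000 nM in this assay, somewhere between 500 nM and 8000 nM.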

Compound 4, half-maximal inhibitory concentration: 9470 nM
Compound 4: the middle estimate sits 4.7-fold (0.68 log units) below what was measured; measured number above the stated range.
By their numbers in this assay, from the lowest: compound 1; then compound 3; then compound 4. At a limit, above all of these: compound 2.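

Swapping 2-chlorophenyl for 4-chlorophenyl on the carbonyl carbon keeps every atom and only moves the chlorine, yet in this assay this gives a 3.8-fold higher number from compound 3 to compound 4 (0.58 log units; beyond the scatter) on the shared core. For the compounds shown here, this is the first pair here that differs in one place, and it shows that the site of the chlorine on this ring alone is enough to weaken inhibition beyond the usual scatter. Nothing at hand explains why the inhibition weakens.

As far as these compounds go, whether a methoxy group or a nitrile in place of the chlorine would show the same preference for the 2-chlorophenyl arrangement remains open. Going by these compounds alone, this single pair also cannot tell whether the same swap would have a similar effect on a core carrying a different group from the one in compound 3 and compound 4.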